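The source may report more compounds than this note shows. Statements on the series, on what has been measured and on what is new or still open speak of the compounds shown alone.

Measured in an assay on isolated protein with Bile acid receptor (Homo sapiens) as the target; a higher number here means that more compound is needed for the effect, a lower number that less compound is needed:
Compound 1, `COC(=O)/C=C/c1cccc(N(Cc2ccc(/C=C/C(=O)O)cc2)C(=O)C2CCCCC2)c1`, gives > 1000 nM, which is a limit of the assay and not a number.
Compound 2, `COC(=O)/C=C/c1cccc(N(Cc2ccc(-c3cc(Cl)ccc3OC)cc2)C(=O)C2CCCCC2)c1`, gives 233 nM.

Going by the values given here, compound 2 therefore holds the only number in this assay; the other value shown is a limit. Among the compounds with values here, the one measured step runs from compound 1 to compound 2: an at least 4.2-fold lower number from compound 1 to compound 2 (0.63 log units; beyond the scatter), and its size is only known as a bound because compound 1 sits at the limit of > 1000 nM in this assay, at which 1 of the 2 values shown sits.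

Compound 3, `COC(=O)/C=C/c1cccc(N(Cc2ccc(-c3cccc(OC(F)(F)F)c3)cc2)C(=O)C2CCCCC2)c1`, differs from compound 2 in one place: 3-(trifluoromethoxy)phenyl in place of 5-chloro-2-methoxyphenyl on an aromatic carbon. Within the data shown here, no measured step concerns this exchange of one aryl group for another; the step from compound 1 to compound 2 replaced a 2-carboxyethenyl group with an aryl group, which is a different kind of change, so it bears on the present step only loosely. Among the measured compounds shown here, with no direct precedent, the expected step from compound 2 to compound 3 in this assay is a 1.3-fold higher number from compound 2 to compound 3 (0.11 log units; within the scatter), that is, no change beyond the scatter. Compound 3 is accordingly estimated at 300 nM, in the range from 90 nM to 1000 nM.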

Compound 3, half-maximal effective concentration: 420 nM
For compound 3 the middle estimate is 1.4-fold (0.15 log units) below the measured one; the measured number falls inside the stated range.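

In this assay, the exchange of 5-chloro-2-methoxyphenyl for 3-(trifluoromethoxy)phenyl on this aromatic carbon gives a 1.8-fold higher number from compound 2 to compound 3 (0.26 log units; within the scatter), so this change of aryl group, with its different substituents, does not move the number beyond the scatter. The second aryl group also stands apart from the 2-carboxyethenyl group, with an at least 2.3-fold lower number from compound 1 to compound 3 (0.37 log units; beyond the scatter), and so the gain first seen with compound 2 is not confined to the 5-chloro-2-methoxyphenyl group. Compound 1 gives > 1000 nM, which is a limit of the assay and not a number, so the size of this step is known only as a bound: the limit of > 1000 nM in this assay, at which 1 of the 3 values shown sits.

From the compounds shown here alone, compound 2 and compound 3 differ in more than one feature of the aryl group, so what the chlorine, the methoxy group or the trifluoromethoxy group each contributes alone remains open, as does the effect of moving any one of them around the ring. Also open, going by these compounds, is how an unsubstituted phenyl group, or an aryl group carrying an amine or a carboxylic acid, would behave on this aromatic carbon.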